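Replacing the trifluoromethyl group of compound 3

The source may report more compounds than this note shows. Statements on the series, on what has been measured and on what is new or still open speak of the compounds shown alone.

Compound 1 `COc1ccc([C@H]2CC(=O)N(Cc3cccc(C#N)c3)C2)cc1OC1CCCC1`: > 10000 nM
Compound 2 `COc1ccc([C@H]2CC(=O)N(c3ccccc3C)C2)cc1OC1CCCC1`: > 10000 nM
Compound 3 `COc1ccc([C@H]2CC(=O)N(c3cccc(C(F)(F)F)c3)C2)cc1OC1CCCC1`: > 10000 nM

All three compounds were tested in a functional assay on HEK293 cells (Homo sapiens) for cytotoxicity (on this read-out lower numbers stand for higher toxicity in this test and higher numbers for lower toxicity in this test), and each entry above is a limit of the assay, not a number. Compound 3 stands with the others at the limit of > 10000 nM in this assay, at which 3 of the 3 values shown sit. The unmeasured compound 4 `COc1ccc([C@H]2CC(=O)N(c3cccc([S+](C)[O-])c3)C2)cc1OC1CCCC1` keeps the shared core and alters one group on the aromatic ring of compound 3: a group of 3 heavy atoms (1 carbon, 1 oxygen, 1 sulfur; no ring) in place of a group of 4 heavy atoms (1 carbon, 3 fluorine; no ring), on an aromatic carbon. The new group sits on an aromatic carbon, meta to a large group.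

The measured steps bear on this change only indirectly, since each of them alters the group on the amide-type nitrogen. They are a step that the two limits leave unreadable from compound 1 to compound 2, a step that the two limits leave unreadable from compound 1 to compound 3 and a step that the two limits leave unreadable from compound 2 to compound 3. None of them has a size that can be read, so they offer no measured effect to carry over. Within the data shown here, the only guide is that compound 3 gives > 10000 nM, a limit, and compound 4 differs from it by a single group. No step beyond the usual scatter is therefore expected in this assay, and no direction is predicted. The expected step is a step that the limit leaves unreadable from compound 3 to compound 4. The assay is expected to report only a limit again. The estimate for compound 4 is 15000 nM, with an expected range from 8000 nM to 50000 nM.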

Compound 4, half-maximal cytotoxic concentration: > 10000 nM
Compound 4 was reported as a limit (the forecaster's own chance of this, stated with the estimate: 85%); the middle value lies beyond the limit too.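

In this assay compound 4 is reported as a limit and not a number, as are compound 1, compound 2 and compound 3, so no step from any of these to compound 4 can be read: the limit of > 10000 nM in this assay, at which 4 of the 4 values shown sit.

The compounds shown leave open where the true values lie and whether exchanging the trifluoromethyl group for the new group changes this read-out at all.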